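This account rests on a few compounds, and the source may have more. Where it says the series, first, only, none or still open, it means among the compounds named here.

Compound 1 `COc1ccc(NC(=O)c2cccc(/C=C3\CC(=O)N(c4ccccc4)C3=O)c2)cc1` is a compound for which an ADME assay on HCT-116 cells (Homo sapiens) for cytotoxicity, read by MTT assay, with a stated time of 72 h (a higher number here means a weaker inhibitor, a lower number a stronger inhibitor), reports only a limit: compound 1 gives > 100000 nM. Compound 2 `CCCCCN1C(=O)C/C(=C\c2cccc(C(=O)Nc3ccc(OC)cc3)c2)C1=O` likewise stands at a limit, as in this assay compound 2 gives > 100000 nM. The step that the two limits leave unreadable from compound 1 to compound 2 cannot be read, since both values rest on (the limit of > 100000 nM in this assay, at which 2 of the 2 values shown sit). Compound 3 `CCOc1ccc(NC(=O)c2cccc(/C=C3\CC(=O)N(c4ccccc4)C3=O)c2)cc1` differs from compound 1 by methyl in place of hydrogen on a saturated chain carbon bound to an oxygen on an aromatic ring. Within the data shown here, no measured step bears on this change, and the two limits give no direction for it. Compound 3 is therefore expected to give 100000 nM, between 30000 nM and 300000 nM, most likely again only a limit. That amounts to an expected step of a number no higher from compound 1 to compound 3 (the limit leaves the size open), nothing beyond the scatter.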

Compound 3, half-maximal inhibitory concentration: 84800 nM
Compound 3: middle estimate off by 1.2-fold (0.07 log units), on the high side; low and high end bracket the measured number.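

In this assay, among these compounds, the change from 4-methoxyphenyl to 4-ethoxyphenyl gives the first readable step at this position: an at least 1.1-fold lower number from compound 1 to compound 3 (0.07 log units; that floor lies within the scatter). Going by these compounds, its size stays open, and only its direction is given, with a floor that does not pass the scatter. Compound 3 carries a measured number, whereas the other compounds shown rest on a limit: the limit of > 100000 nM in this assay, at which 2 of the 3 values shown sit.

The compounds shown leave open what a longer chain such as propoxy, or an amine, would do in place of the ethoxy group. They also leave open whether ethoxy would give a measurable number with pentyl on the amide-type nitrogen in the ring.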